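The source may hold more compounds than are shown below. What is called first, only, known or untested is meant among the compounds shown, and "the series" means these compounds.

Measured so far: compound 1 `CCC(F)(F)C(=O)N1CCC(Oc2ncnc(Oc3ccc(S(C)(=O)=O)nc3C)c2F)CC1` with 69.2 nM; compound 2 `Cc1nc(S(C)(=O)=O)ccc1Oc1ncnc(OC2CCN(C(=O)c3nc(C(C)(C)F)no3)CC2)c1F` with 606 nM.

Going by the values given here, in a functional assay on isolated protein for inhibition of Glucose-dependent insulinotropic receptor (Rattus norvegicus), read by HTRF and cAMP accumulation (a higher number here means that more compound is needed for the effect, a lower number that less compound is needed), compound 1 gives 69.2 nM, and compound 2 gives 606 nM, which is the higher of the two numbers; the only measured step, an 8.8-fold higher number from compound 1 to compound 2 (0.94 log units; beyond the scatter), separates them. Compound 3 `CCc1cnc(C(=O)N2CCC(Oc3ncnc(Oc4ccc(S(C)(=O)=O)nc4C)c3F)CC2)nc1` has not been measured in this assay. It differs from compound 2 in one place: a group of 8 heavy atoms (6 carbon, 2 nitrogen; one six-membered aromatic ring with 2 hetero atoms) in place of a group of 9 heavy atoms (5 carbon, 2 nitrogen, 1 oxygen, 1 fluorine; one five-membered aromatic ring with 3 hetero atoms), on a carbonyl carbon. Among the compounds with values here, the one measured step bears on it only loosely, since it replaced a chain without a ring by the five-membered aromatic ring and brought the higher number for compound 2; the change to compound 3 swaps one aromatic ring on that carbonyl carbon for another, so there is no step of the same kind to lean on. Given that the ring-bearing compound 2 stands at 606 nM, compound 3 is expected to stay nearer that number than to compound 1, with a modest lower number allowed for, the expected step being a 2.4-fold lower number from compound 2 to compound 3 (0.38 log units; beyond the scatter). For compound 3 the estimate is 250 nM, within 60 nM to 1000 nM.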

Compound 3, half-maximal effective concentration: 40.8 nM
Compound 3: the middle estimate sits 6.1-fold (0.79 log units) above what was measured; the whole stated range lies above it.
By their numbers in this assay, from the lowest: compounds 3 and 1 (each within the scatter of the next); then compound 2.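

On the carbonyl carbon whose other neighbour is an amide-type nitrogen in a ring, a ring as such does not go with the higher number in this assay: putting 5-ethylpyrimidin-2-yl in place of the five-membered aromatic ring gives a 15-fold lower number from compound 2 to compound 3 (1.17 log units; beyond the scatter), a large step in the opposite direction to the first one. Against the ring-free 1,1-difluoropropyl group, the same 5-ethylpyrimidin-2-yl group gives a 1.7-fold lower number from compound 1 to compound 3 (0.23 log units; within the scatter), so a six-membered aromatic ring and an open chain cannot be told apart at this position in this assay. The earlier step therefore no longer reads as a penalty for replacing a chain with a ring, and among these three compounds only compound 2 stands apart. No measurement is available here that would explain why these groups differ.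

The compounds shown leave open whether the ethyl group on the pyrimidine contributes at all, since an unsubstituted pyrimidin-2-yl, a longer chain such as propyl, or an amine there would each test this. They also leave open whether the higher number of compound 2 follows from its five-membered ring or from the fluorinated branched group that the ring carries.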